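Setting One Stereocentre in the Chain

The compounds below may be only part of what the source reports. "The series", "measured", "known", "first", "only" and "open" are said of these compounds alone.

In a functional assay on HCT-116 cells (Homo sapiens) for antiproliferative activity, read by MTT assay, with a stated time of 48 h (a higher number here means a weaker inhibitor, a lower number a stronger inhibitor), compound 1 `CCCCCCCCC[C@H](CCO)n1cnc2c(Cl)ncnc21` gives 450 nM and compound 2 `CCCCCCCCC[C@H](CCOS(C)(=O)=O)n1cnc2c(Cl)ncnc21` gives 9480 nM. Compound 3 `CCCCCCCCCC(CCN=[N+]=[N-])n1cnc2c(Cl)ncnc21` gives 1040 nM, the middle of these three numbers. Compound 4 `CCCCCCCCC[C@H](CCN=[N+]=[N-])n1cnc2c(Cl)ncnc21` differs from it only in how one stereocentre is drawn: the two compounds have the same atoms and bonds; at least one stereo element is drawn with a configuration in one of them and without one in the other: 1 of 2 stereo elements differ; a stereocentre at a saturated chain carbon is drawn without a configuration in compound 3 and R in compound 4. For the measured compounds named here, the single measured step, a 21-fold higher number from compound 1 to compound 2 (1.32 log units; beyond the scatter), is large, but it replaces a group and leaves the configuration unchanged, and it gives no size for this change. Going by the values given here, no measured pair tests a configuration. No step beyond the scatter is expected, and the estimated step is a 1.2-fold lower number from compound 3 to compound 4 (0.06 log units; within the scatter). Compound 4 is expected at 900 nM, with an estimated range of 400 nM to 2000 nM.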

Compound 4, half-maximal inhibitory concentration: 1190 nM
Compound 4: middle estimate off by 1.3-fold (0.12 log units), on the low side; measured number inside the range.
By their numbers in this assay, from the lowest: compound 1; then compounds 3 and 4 (each within the scatter of the next); then compound 2.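

In this assay the step is a 1.1-fold higher number from compound 3 to compound 4 (0.06 log units; within the scatter), the first measured test of a configuration in this series, and it shows no change beyond the scatter at this chain carbon. What this pair compares is limited to a defined and an undefined drawing: the fact that one of compounds 3 and 4 is drawn with a defined configuration and the other without, at the place where they differ. Among the compounds with a drawn configuration, azido reads weaker than hydroxy and stronger than (methylsulfonyl)oxy, with a 2.6-fold higher number from compound 1 to compound 4 (0.42 log units; beyond the scatter) and an 8.0-fold lower number from compound 2 to compound 4 (0.90 log units; beyond the scatter).

Going by these compounds, how the S configuration would read stays open. So does where an amine in place of azido on this carbon would fall.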